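The source may hold more compounds than are shown below. What is called first, only, known or untested is meant among the compounds shown, and "the series" means these compounds.

Working notes on the series. Compound 1 `Cn1c(-c2ccc(NC(=O)CSc3nc4cc(Cl)ccc4o3)cc2)nc(-c2ccccc2)c1-c1ccccc1` is the point of reference; in a functional assay on MCF7 cells (Homo sapiens) for cytotoxicity, read by MTT assay, with a stated time of 24 h, tested at 1.6 ug/mL (on this read-out higher numbers stand for a stronger effect at the one concentration tested and lower numbers for a weaker effect), compound 1 gives 2.5%. Compound 2 `Cc1ccc2oc(SCC(=O)Nc3ccc(-c4nc(-c5ccccc5)c(-c5ccccc5)n4C)cc3)nc2c1` gives 1.9%, and compound 3 `Cn1c(-c2ccc(NC(=O)CSC3=NCCS3)cc2)nc(-c2ccccc2)c1-c1ccccc1` gives 16.2%. Compound 1 thus stands second highest of the three numbers, with compound 2 nearest and compound 3 furthest: the step of a number 0.6 percentage points lower from compound 1 to compound 2 (within the scatter) is within the scatter, whereas a number 13.7 percentage points higher from compound 1 to compound 3 (beyond the scatter) lies beyond it.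

Compound 4 `CN1CCN(CC(=O)Nc2ccc(-c3nc(-c4ccccc4)c(-c4ccccc4)n3C)cc2)CC1` has not yet been measured; it differs from compound 1 by 4-methylpiperazin-1-yl in place of (5-chloro-1,3-benzoxazol-2-yl)sulfanyl on a saturated chain carbon bound to a carbonyl carbon. Among the compounds with values here, the steps that bear on this are the change to compound 3 already noted and a number 14.3 percentage points higher from compound 2 to compound 3 (beyond the scatter), both modest rises when a group of 5 heavy atoms with one five-membered non-aromatic ring replaced a group of 10 heavy atoms on the sulfur. In compound 4 the sulfur itself leaves and the entering ring is six-membered and non-aromatic, so those steps are only a loose guide. A modest rise is expected for compound 4, a number 7.5 percentage points higher from compound 1 to compound 4 (within the scatter), with wide uncertainty. Compound 4 is estimated in this assay at 10%, between 0% and 28%.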

Compound 4, a percentage reported as activity, at one concentration (the size of the read-out at that concentration, not a potency): 2.9%
Estimate against measurement, compound 4: 7.1 percentage points above; the measured number falls inside the stated range.
By their numbers in this assay, from the lowest: compounds 2, 1 and 4 (each within the scatter of the next); then compound 3.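

In this assay, 4-methylpiperazin-1-yl in place of (5-chloro-1,3-benzoxazol-2-yl)sulfanyl on a saturated chain carbon bound to a carbonyl carbon gives a number 0.4 percentage points higher from compound 1 to compound 4 (within the scatter), and in place of (5-methyl-1,3-benzoxazol-2-yl)sulfanyl it gives a number 1 percentage points higher from compound 2 to compound 4 (within the scatter), so this exchange does not separate the new group from either benzoxazole group. With a number 13.3 percentage points lower from compound 3 to compound 4 (beyond the scatter), a non-aromatic ring at this place does not by itself match compound 3, and the earlier rises do not extend to compound 4. No measured evidence bears on why compound 3 stands apart from compound 4.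

The compounds shown leave open whether morpholin-4-yl or an open-chain amine such as diethylamino on the same carbon would read with compound 3 or with compound 4. They also leave open whether the sulfur on the chain, the sulfur in the ring of compound 3, or both go with its number.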